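The compounds below may be only part of what the source reports. "The series", "measured", "known", "first", "only" and "open" are said of these compounds alone.

For the measured compounds named here, compound 2 `CNC(=O)c1cccc(Cn2nc(C)c(NC(=O)c3ccc(COc4ccccc4OC)cc3)c2C)c1` is one of two compounds measured in a functional assay on MIA PaCa-2 cells (Homo sapiens) for antiproliferative activity, read by MTT assay, with a stated time of 72 h; a lower number here means that less compound is needed, a higher number that more compound is needed for the effect. Compound 2 gives 8500 nM, the highest of the two numbers. Its closest relative, compound 1 `CNC(=O)c1cccc(Cn2nc(C)c(NC(=O)c3ccc(COc4ccccc4C)cc3)c2C)c1`, gives 2100 nM in this assay. Going by the values given here, the single measured step, a 4.0-fold higher number from compound 1 to compound 2 (0.61 log units; beyond the scatter), comes from methoxy in place of methyl on an aromatic carbon.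

Compound 3 `CNC(=O)c1cccc(Cn2nc(C)c(NC(=O)c3ccc(COc4cccc(Cl)c4)cc3)c2C)c1` has not yet been measured. Its difference from compound 2 is 3-chlorophenyl in place of 2-methoxyphenyl on an oxygen on a saturated carbon. The measured step bears on it only loosely: it shows that exchanging a small group on this ring moved the number modestly, and that the methoxy version sits at the higher end. As far as these compounds go, because a 4.0-fold higher number from compound 1 to compound 2 (0.61 log units; beyond the scatter) places the methoxy version at the higher end, a lower number is expected for compound 3 once the methoxy is lost, while the chlorine is untested. Compound 3 is therefore estimated at 3500 nM, within 900 nM to 14000 nM, an expected step of a 2.4-fold lower number from compound 2 to compound 3 (0.39 log units; beyond the scatter).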

Compound 3, half-maximal effective concentration: 5900 nM
Compound 3: middle estimate off by 1.7-fold (0.23 log units), on the low side; the range from low to high includes it.
By their numbers in this assay, from the lowest: compound 1; then compounds 3 and 2 (each within the scatter of the next).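

In this assay the exchange of 2-methoxyphenyl for 3-chlorophenyl on this oxygen gives a 1.4-fold lower number from compound 2 to compound 3 (0.16 log units; within the scatter) and so does not separate compound 2 from compound 3. Set against 2-methylphenyl, the same 3-chlorophenyl group gives a 2.8-fold higher number from compound 1 to compound 3 (0.45 log units; beyond the scatter) and leaves compound 1 with the lowest number of the three, its steps to both others being beyond the scatter. Neither of the two other groups tried here matches 2-methylphenyl, although each step changes both the group on the ring and its place there, so the two effects cannot be separated.

As far as these compounds go, how a plain phenyl, or a ring carrying an amine or a carboxylic acid, would read on this oxygen stays open. What lies behind these differences also stays open, as nothing available here explains them.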